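Hydroxyl Added to an Alkynyl Side Chain: Expected Cytotoxicity

The compounds below may be only part of what the source reports. "The series", "measured", "known", "first", "only" and "open" are said of these compounds alone.

Measured so far:
- compound 1, `O=c1[nH]cc(C#CC2CC2)c(=O)[nH]1`: 252000 nM
- compound 2, `O=c1[nH]c(=O)n([C@@H]2O[C@H](CO)[C@@H](O)[C@H]2O)cc1C#Cc1ccccc1`: 78400 nM

In an ADME assay on Vero cells (Chlorocebus sabaeus) for cytotoxicity, read by MTT assay (on this read-out lower numbers stand for higher toxicity in this test and higher numbers for lower toxicity in this test), compound 1 gives 252000 nM. In this assay compound 2 gives 78400 nM, the lowest of the two numbers recorded, which means compound 2 is the more toxic of the pair; its distance to compound 1 is beyond the scatter of this test.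

Compound 3, `O=c1[nH]c(=O)n([C@@H]2O[C@H](CO)[C@@H](O)[C@H]2O)cc1C#CC(O)c1ccccc1`, is not yet measured. It differs from compound 2 by hydroxy(phenyl)methyl in place of phenyl on a triple-bonded carbon. The rest of the molecule, including the sugar and the shared core, is unchanged.

Within the data shown here, no pair of measured compounds differs in just one place, so there is no measured step to lean on. A change of this kind, adding a single hydroxyl to a side chain, is expected to move the number little, most likely within the scatter or slightly upward toward lower toxicity. The estimated step from compound 2 to compound 3 is a 1.3-fold higher number from compound 2 to compound 3 (0.11 log units; within the scatter). For compound 3 the expected value in this assay is 100000 nM, with a range from 40000 nM to 250000 nM.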

Compound 3, half-maximal cytotoxic concentration: 65400 nM
Compound 3: the middle estimate sits 1.5-fold (0.18 log units) above what was measured; the measured number falls inside the stated range.
By their numbers in this assay, from the lowest: compounds 3 and 2 (each within the scatter of the next); then compound 1.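

In this assay, among these compounds, the change of phenyl to hydroxy(phenyl)methyl on a triple-bonded carbon gives a 1.2-fold lower number from compound 2 to compound 3 (0.08 log units; within the scatter) and so offers the first comparison of compounds that differ in one place. It shows that this position can carry the larger group, with its 1 hydrogen-bond donor and 1 hydrogen-bond acceptor, without a change in the number that stands out from the scatter of the test. No measurement here offers an explanation for this result.

The compounds shown leave open whether an amine or a carboxylic acid in place of the hydroxyl, or a longer chain in place of hydroxy(phenyl)methyl, would also stay within the scatter of compound 2 in this assay. They also leave open whether the same change on a triple-bonded carbon would give a similarly small step with the cyclopropyl group of compound 1 or on a compound without the sugar.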